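A few compounds are considered here, and "the series" means these few. Any claim that something is new, unique, unknown or untested is made for them only; others in the source may bear on it.

Compounds measured so far:
- compound 1, `COc1ccc(-c2cn(CC(=O)Nc3nc4ccccc4s3)nn2)cc1` — 1330 nM
- compound 2, `COc1cccc(-c2cn(-c3ccc(C(F)(F)F)cc3)nc2C(=O)NC2CCCCC2)c1` — > 30000 nM
- compound 3, `Nc1cccc(-c2cn(CC(=O)Nc3nccs3)nn2)c1` — 1270 nM

The read-out throughout is a functional assay on BMDM cells (Mus musculus, strain C57BL/6) for inhibition, with a stated time of 2 days; a lower number here means a stronger inhibitor, a higher number a weaker inhibitor. Compound 1 gives 1330 nM, and compound 3 gives 1270 nM. Compound 2 is a different case: in this assay compound 2 reaches only > 30000 nM, which is a limit of the assay rather than a measured number. Compound 2 thus stands at the limit of > 30000 nM in this assay, at which 1 of the 3 values shown sits, with no figure of its own to compare against the other two.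

The compound that has not yet been measured is compound 4, `COc1cccc(-c2cn(-c3ccc(C(F)(F)F)cc3)nc2C(=O)NCCCN(C)C)c1`. It is built on the core of compound 2 and differs from it in a single place: 3-(dimethylamino)propyl in place of cyclohexyl on an amide-type nitrogen. Going by the values given here, no pair of measured compounds shows this particular exchange, so the size of its effect cannot be read from the numbers in hand.

Compound 2 sits at the limit (the limit of > 30000 nM in this assay, at which 1 of the 3 values shown sits), so compound 4 is expected to stay weak as well, with a step of a number no higher from compound 2 to compound 4 (the limit leaves the size open) that amounts to no change beyond the scatter; in this assay compound 4 is estimated at 30000 nM, between 6000 nM and 80000 nM, and a limit rather than a number is the more likely outcome.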

Compound 4, half-maximal inhibitory concentration: > 30000 nM
Compound 4 gave a limit, no number; the forecaster's own chance of this, stated with the estimate: 70%; the middle value lies on the limit itself.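

Compound 2 and compound 4 both end at a limit rather than a number, so the step between them cannot be read: the limit of > 30000 nM in this assay, at which 2 of the 4 values shown sit. The compounds shown leave open whether 3-(dimethylamino)propyl in place of cyclohexyl on the amide-type nitrogen changes inhibition at all.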